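Aryl substitution on the shared core: working notes

A few compounds are considered here, and "the series" means these few. Any claim that something is new, unique, unknown or untested is made for them only; others in the source may bear on it.

Values in a functional assay on SW-620 cells (Homo sapiens) for cytotoxicity, read by sulforhodamine B assay, with a stated time of 48 h; a lower number here means a stronger inhibitor, a higher number a weaker inhibitor:
- compound 1 `COc1ccc(C2=NO[C@]3(C2)C(=O)O[C@@H]2[C@H]3CC[C@H](C)[C@]3(O)C=CC(=O)[C@@]23C)cc1`: 41000 nM
- compound 2 `C[C@H]1CC[C@@H]2[C@@H](OC(=O)[C@]23CC(c2ccccc2)=NO3)[C@]2(C)C(=O)C=C[C@@]12O`: 45400 nM

Compound 2 lies within the scatter of compound 1, so the two stand level on these numbers. Next comes compound 3 `C[C@H]1CC[C@@H]2[C@@H](OC(=O)[C@]23CC(c2ccc(N(C)C)cc2)=NO3)[C@]2(C)C(=O)C=C[C@@]12O`, with dimethylamino in place of hydrogen on an aromatic carbon, para to a large group: dimethylamino in place of hydrogen on an aromatic carbon. Among the measured compounds shown here, the only measured step on an aromatic carbon, a 1.1-fold higher number from compound 1 to compound 2 (0.04 log units; within the scatter), swaps hydrogen for methoxy and stays within the scatter. This single step gives no ground for expecting a change beyond the scatter in this assay. The expected step is a 1.2-fold lower number from compound 2 to compound 3 (0.08 log units; within the scatter). For compound 3 the estimated value is 38000 nM, with an expected range of 16000 nM to 80000 nM.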

Compound 3, half-maximal inhibitory concentration: 5100 nM
The estimate for compound 3 lay 7.5-fold (0.87 log units) above the measured number; the measured number lies below the stated range.
By their numbers in this assay, from the lowest: compound 3; then compounds 1 and 2 (each within the scatter of the next).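

At this aromatic carbon, para to a large group, the substituent can shift the number in this assay beyond the scatter: dimethylamino in place of hydrogen gives an 8.9-fold lower number from compound 2 to compound 3 (0.95 log units; beyond the scatter), and dimethylamino in place of methoxy gives an 8.0-fold lower number from compound 1 to compound 3 (0.91 log units; beyond the scatter). Compound 1 and compound 2 stood level, so the position had looked insensitive, and methoxy and dimethylamino do not read alike here. Nothing at hand bears on the cause of these steps.

Going by these compounds, whether a primary amine, a morpholine or a carboxylic acid at this carbon would give a similar number stays open.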